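Replacing isopropylcarbamoyl with phenylsulfonyl on an amine nitrogen

The source may hold more compounds than are shown below. What is called first, only, known or untested is meant among the compounds shown, and "the series" means these compounds.

Of the compounds shown here, two have been tested in an ADME assay on microsomes from liver (Homo sapiens) for metabolic stability, read by LC-MS, with NADPH named in the record, with a stated time of 60 min, tested at 1 uM, in the absence of a further agent; on this read-out higher numbers stand for a more stable compound and lower numbers for a less stable compound: compound 1 (`CC(=O)N[C@@H]1CCN(c2cc(C)nn3c(-c4cccc(S(=O)(=O)N(C)C)c4)c(C)nc23)C1`) and compound 2 (`COc1ccc(-c2c(C)nc3c(N4CC[C@@H](NC(=O)NC(C)C)C4)cc(C)nn23)cc1OC`). Compound 1 gives > 95%, which is a limit and not an exact number. Compound 2 gives > 95%, which is also a limit, so its true standing is not known exactly.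

Compound 3 (`COc1ccc(-c2c(C)nc3c(N4CC[C@@H](NS(=O)(=O)c5ccccc5)C4)cc(C)nn23)cc1OC`) has not yet been measured. It keeps the core of compound 2 but carries phenylsulfonyl in place of isopropylcarbamoyl on an amine nitrogen. Within the data shown here, no measured pair shows what a change of this kind does. Stability is expected to stay fairly high because of the limit of > 95% in this assay, at which 2 of the 2 values shown sit. The expected change is a modest fall, a number at least 9 percentage points lower from compound 2 to compound 3 (that floor lies within the scatter), which may not clear the usual scatter. For compound 3 the estimate in this assay is 86%, with an expected range from 62% to 99%.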

Compound 3, percent of the compound remaining: > 95%
Compound 3: only a limit was reported; the forecaster's own chance of this, stated with the estimate: 30%; middle value at least 9 percentage points away from the limit.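

In this assay compound 3 gives > 95%, which is a limit. Compound 2 also stands at a limit, so no step can be read from it to compound 3: the limit of > 95% in this assay, at which 3 of the 3 values shown sit.

The compounds shown leave open whether phenylsulfonyl in place of isopropylcarbamoyl changes stability at all.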